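The source may report more compounds than this note shows. Statements on the series, on what has been measured and on what is new or still open speak of the compounds shown alone.

Measured compounds in an assay on CHO cells for antagonist activity at transient receptor potential cation channel subfamily V member 1 (Homo sapiens), read by FLIPR; on this read-out higher numbers stand for weaker inhibition and lower numbers for stronger inhibition:
compound 1, `CC(C(=O)NCc1ccc(C(F)(F)F)cc1N1CCC(Cc2ccccc2)CC1)c1ccc(NS(C)(=O)=O)c(F)c1`: 1.4 nM
compound 2, `CC(C(=O)NCc1ccc(C(F)(F)F)cc1N1CCC(Cc2ccc(F)cc2)CC1)c1ccc(NS(C)(=O)=O)c(F)c1`: 0.4 nM
compound 3, `CC(C)CCOc1cc(C(F)(F)F)ccc1CNC(=O)C(C)c1ccc(NS(C)(=O)=O)c(F)c1`: 0.5 nM

All three share the same core, an amide bearing the methanesulfonamide-substituted aryl group, and differ only in the substituent on the benzylic ring that carries the trifluoromethyl group. Among the measured compounds shown here, the one step that can be traced within a single change is a 3.5-fold lower number from compound 1 to compound 2 (0.54 log units; beyond the scatter). Compound 3 sits between the other two: its number lies within the scatter of that of compound 2, and it is separated from compound 1 by a gap beyond the scatter, compound 1 having the higher number of the three.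

Compound 4, `CC(C(=O)NCc1ccc(C(F)(F)F)cc1C1CCCCC1)c1ccc(NS(C)(=O)=O)c(F)c1`, is not yet measured. It differs from compound 3 by cyclohexyl in place of isopentyloxy on an aromatic carbon; the hydrogen-bond acceptor of the isopentyloxy group is lost, and a carbocyclic ring takes the place of the chain. For the measured compounds named here, no measured pair mirrors this exchange, and the one step known, from compound 1 to compound 2, concerns a fluorine on a distant aromatic ring, so it offers little guidance here. The three measured compounds all sit at very low numbers despite carrying quite different groups at this position, which suggests the site tolerates variation. Compound 4 is therefore expected to stay potent, with a step of a 3.0-fold higher number from compound 3 to compound 4 (0.48 log units; beyond the scatter) that may be somewhat weaker but likely within or only just beyond the scatter. The estimate for compound 4 is 1.5 nM, with a range from 0.4 nM to 6 nM.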

Compound 4, inhibition constant: 0.6 nM
Compound 4: the middle estimate sits 2.5-fold (0.40 log units) above what was measured, and the stated range covers the measured number.
By their numbers in this assay, from the lowest: compounds 2, 3 and 4 (each within the scatter of the next); then compound 1.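

In this assay, cyclohexyl in place of isopentyloxy on this aromatic carbon gives a 1.2-fold higher number from compound 3 to compound 4 (0.08 log units; within the scatter), so the read-out does not separate the two groups. This is the first step shown that changes this position alone, whereas the earlier compounds could only suggest tolerance there, through groups that differed in more than one respect and without a single-change comparison. Here, an open chain with 1 hydrogen-bond acceptor gives way to a six-membered ring of carbon only with 0 hydrogen-bond acceptors, at an equal count of 6 heavy atoms, and the number stays within the scatter, although no measurement shown here offers an explanation for this.

The compounds shown leave open how this aromatic carbon would respond to a group of a different kind, such as an amine or a carboxylic acid, or to a much shorter group such as methoxy. Going by these compounds, it also remains open how a phenyl ring or a bare hydrogen at this position would compare with cyclohexyl in this assay.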